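This account rests on a few compounds, and the source may have more. Where it says the series, first, only, none or still open, it means among the compounds named here.

Measured so far in a functional assay on DU-145 cells (Homo sapiens) for cytotoxicity, read by MTT assay, with a stated time of 48 h; a higher number here means a weaker inhibitor, a lower number a stronger inhibitor:
compound 1 `CCOC(=O)c1c(-c2c(Cl)c3cc(C)ccc3oc2=O)nn(-c2ccccc2)c1C(=O)OCC`: 50000 nM
compound 2 `CCOC(=O)c1c(-c2c(Cl)c3cc(C)ccc3oc2=O)nn(-c2cccc(C)c2)c1C(=O)OCC`: 103000 nM
compound 3 `CCOC(=O)c1c(-c2cc3ccccc3oc2=O)nn(-c2ccccc2)c1C(=O)OCC`: 57000 nM

Compound 3 gives the second highest of the three numbers, but its gap to compound 1 and its gap to compound 2 both lie within the scatter, so the three compounds cannot be separated on these data. Compound 4 `CCOC(=O)c1c(-c2cc3ccccc3oc2=O)nn(-c2ccc(Br)cc2)c1C(=O)OCC` differs from compound 3 by bromo in place of hydrogen on an aromatic carbon. Among the compounds with values here, only one measured step bears on a substituent on that phenyl: a 2.1-fold higher number from compound 1 to compound 2 (0.31 log units; beyond the scatter), a modest rise in the number, though with a different group at a different place on the ring and on a different core. Taken loosely, it points to a small rise or to no step beyond the scatter, and the width of the range should reflect that the guide is a single step. For compound 4 the step of a 1.3-fold higher number from compound 3 to compound 4 (0.12 log units; within the scatter) is expected. Compound 4 is estimated at 75000 nM, with a range from 30000 nM to 180000 nM.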

Compound 4, half-maximal inhibitory concentration: 61000 nM
Compound 4: middle estimate off by 1.2-fold (0.09 log units), on the high side; measured number inside the range.
By their numbers in this assay, from the lowest: compounds 1, 3, 4 and 2 (each within the scatter of the next, the first and the last beyond it).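

In this assay, the change from phenyl to 4-bromophenyl, with bromo para to a large group, gives a 1.1-fold higher number from compound 3 to compound 4 (0.03 log units; within the scatter), so compound 4 cannot be separated from compound 3. Within the data shown here, the only earlier step on this ring, a 2.1-fold higher number from compound 1 to compound 2 (0.31 log units; beyond the scatter), involves methyl at a different place and on a different core, so it does not show how this place responds; the new step shows that here a bromo group brings no step beyond the scatter. Nothing available accounts for this result.

From the compounds shown here alone, it remains open whether an amine or a carboxylic acid at this place would give a number beyond the scatter from compound 3. Also open, going by these compounds, is whether bromo gives a similar step on the core of compound 1.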